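The compounds below may be only part of what the source reports. "The series", "measured", "known", "first", "only" and "open" are said of these compounds alone.

Measured so far in a functional assay on PC-3 cells (Homo sapiens) for inhibition, read by sulforhodamine B assay, with a stated time of 48 h, tested at 50 uM; on this read-out lower numbers stand for less inhibition of growth and higher numbers for more inhibition of growth at the one concentration tested:
Compound 1 `CCCOc1ccc([C@@H]2CC(=O)c3cc(CC=C(C)C)c(OC)cc3O2)cc1`: 54%
Compound 2 `COc1cc2c(cc1CC=C(C)C)C(=O)C[C@@H](c1ccc(Oc3cccc([N+](=O)[O-])c3)cc1)O2`: 21%
Compound 3 `COc1cc2c(cc1CC=C(C)C)/C(=N/NC(N)=O)C[C@@H](c1ccc(O)cc1)O2`: 67%

Compound 2 stands lowest of the three, with compound 1 and compound 3 both higher beyond the scatter. Compound 4 `CCOc1ccc([C@@H]2CC(=O)c3cc(CC=C(C)C)c(OC)cc3O2)cc1` has not yet been measured. It departs from compound 2 as follows: ethyl in place of 3-nitrophenyl on an oxygen on an aromatic ring. Among the compounds with values here, one measured step bears on this change, a number 33 percentage points lower from compound 1 to compound 2 (beyond the scatter), a large drop where 3-nitrophenyl replaced propyl. Compound 4 reverses that swap, with ethyl rather than propyl, so a rise of similar size, beyond the scatter, is expected in this assay. The estimate implies an expected step of a number 29 percentage points higher from compound 2 to compound 4 (beyond the scatter). The expected value for compound 4 is 50%, with an estimated range from 36% to 64%.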

Compound 4, percent growth inhibition at one concentration: 60%
For compound 4 the middle estimate is 10 percentage points below the measured one, within the range that was stated.
By their numbers in this assay, from the lowest: compound 2; then compounds 1, 4 and 3 (each within the scatter of the next, the first and the last beyond it).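

In this assay the return from 3-nitrophenoxy to ethoxy gives a number 39 percentage points higher from compound 2 to compound 4 (beyond the scatter) and so shows the low number of compound 2 from a second comparison. Ethyl and propyl on this oxygen cannot be told apart, with a number 6 percentage points higher from compound 1 to compound 4 (within the scatter) as the step, so compound 2 alone stands apart among these three. Nothing on hand accounts for this difference. The compounds shown leave open how a butyl chain on this oxygen would read, and whether an unsubstituted phenyl would read like 3-nitrophenyl or like the short chains.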